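A Nitro in Place of a Methoxy

This account rests on a few compounds, and the source may have more. Where it says the series, first, only, none or still open, it means among the compounds named here.

In a functional assay on MCF7 cells (Homo sapiens) for antiproliferative activity, read by MTT assay, with a stated time of 48 h (on this read-out higher numbers stand for weaker inhibition and lower numbers for stronger inhibition), compound 1 `Cc1cc2nc(NC(c3cn(-c4ccccc4)nc3-c3ccc([N+](=O)[O-])cc3)c3c(O)ccc4ccccc34)sc2cc1C` gives 41100 nM and compound 2 `COc1ccc(-c2nn(-c3ccccc3)cc2C(Nc2nc3ccccc3s2)c2c(O)ccc3ccccc23)cc1` gives 17500 nM as its reading. Compound 2 therefore stands lowest of the two, and its gap to compound 1 lies beyond the scatter. Compound 3 `O=[N+]([O-])c1ccc(-c2nn(-c3ccccc3)cc2C(Nc2nc3ccccc3s2)c2c(O)ccc3ccccc23)cc1` remains unmeasured. The change nitro in place of methoxy on an aromatic carbon turns the 4-methoxyphenyl of compound 2 into 4-nitrophenyl, with nitro in place of methoxy on an aromatic carbon, para to a large group. For the measured compounds named here, no measured pair isolates this change. Compound 1 at 41100 nM also carries 4-nitrophenyl but differs from compound 3 elsewhere too, so it offers only a loose guide. A small step toward a higher number in this assay is expected, perhaps none beyond the scatter. The estimated step is a 1.5-fold higher number from compound 2 to compound 3 (0.17 log units; within the scatter) on this reading. Compound 3 is expected at 26000 nM with an estimated range from 10000 nM to 60000 nM in this measurement.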

Compound 3, half-maximal inhibitory concentration: 14700 nM
The estimate for compound 3 lay 1.8-fold (0.25 log units) above the measured number, within the range that was stated.
By their numbers in this assay, from the lowest: compounds 3 and 2 (each within the scatter of the next); then compound 1.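

In this assay, 4-nitrophenyl in place of 4-methoxyphenyl gives a 1.2-fold lower number from compound 2 to compound 3 (0.08 log units; within the scatter), so the two groups cannot be told apart at this position, para to a large group. Compound 3 also forms a pair with compound 1 that differs in one place: 1,3-benzothiazol-2-yl in place of 5,6-dimethyl-1,3-benzothiazol-2-yl on the amine nitrogen gives a 2.8-fold lower number from compound 1 to compound 3 (0.45 log units; beyond the scatter), a modest step but one beyond the scatter, and so in this series a change at that place registers where the nitro-for-methoxy change does not. Nothing measured here gives a reason for either step.

From the compounds shown here alone, whether an amine or a carboxylic acid at the para position would read differently from methoxy and nitro remains open. Going by these compounds, it is also open whether the step on the amine nitrogen would recur with 4-methoxyphenyl in place of 4-nitrophenyl.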